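A Hydroxy Group Added to Two Different Cores

The source may hold more compounds than are shown below. What is called first, only, known or untested is meant among the compounds shown, and "the series" means these compounds.

Of the compounds shown here, three have so far been tested in a functional assay on HepG2 cells (Homo sapiens) for antiproliferative activity, read by fluorescence and resazurin assay, with a stated time of 48 h; on this read-out lower numbers stand for stronger inhibition and higher numbers for weaker inhibition. Compound 3 `Cc1noc(NS(=O)(=O)c2ccc(NC(=O)c3cc4ccccc4oc3=O)cc2)c1C` gives 24000 nM in this assay. Compound 1 `Cc1noc(NS(=O)(=O)c2ccc(NC(=O)c3cc4ccc(O)cc4oc3=O)cc2)c1C` differs from it by hydroxy in place of hydrogen on an aromatic carbon and gives 38800 nM in this assay; the step from one to the other is a 1.6-fold higher number from compound 3 to compound 1 (0.21 log units; within the scatter). Compound 2 `CCOc1ccc2nc(Cl)c(/C=N/NC(=O)c3cc4ccccc4oc3=O)cc2c1` is built on a different core, and the difference between the two cores is not broken down here. In this assay compound 2 gives 33100 nM, a value that sits within the scatter of both compound 1 and compound 3.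

Compound 4 `CCOc1ccc2nc(Cl)c(/C=N/NC(=O)c3cc4ccc(O)cc4oc3=O)cc2c1` has not yet been measured. It stands to compound 2 exactly as compound 1 stands to compound 3: hydroxy in place of hydrogen on an aromatic carbon, at the same place of the ring system. Among the measured compounds shown here, the step is expected to be a 1.4-fold higher number from compound 2 to compound 4 (0.13 log units; within the scatter), because the one earlier example of this change, a 1.6-fold higher number from compound 3 to compound 1 (0.21 log units; within the scatter), stayed within the scatter. Compound 4 is therefore estimated to give about 45000 nM in this assay, with a likely range from 18000 nM to 110000 nM.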

Compound 4, half-maximal inhibitory concentration: 19200 nM
Beside the measured number, compound 4's estimate is 2.3-fold (0.37 log units) above it; measured number inside the range.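

In this assay, putting hydroxy in place of hydrogen on an aromatic carbon gives a 1.7-fold lower number from compound 2 to compound 4 (0.24 log units; within the scatter) and so, taken alone, this step is no larger than repeated measurements can produce. Set beside the earlier example, however, the change does not carry over from one core to the other as a single fixed shift: the same change on two cores in this assay, a 1.6-fold higher number (0.21 log units; within the scatter) from compound 3 to compound 1 and a 1.7-fold lower number (0.24 log units; within the scatter) from compound 2 to compound 4, 2.8-fold (0.45 log units) apart, beyond the scatter of two such steps. What this does not show is a dependable direction on either core: each step alone lies within the scatter, and two pairs of compounds give neither a rule for further cores nor a reason for the gap.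

The compounds shown carry only hydroxy at this one place, so it remains open whether an amine, a methoxy group or a carboxylic acid there would move the number further on either core. Going by these compounds, it also remains open whether hydroxy at another place on the same ring would behave as it does here.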